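Swapping Butoxy for Pyrrolidin-1-yl on a Carbonyl Carbon

The compounds below may be only part of what the source reports. "The series", "measured", "known", "first", "only" and "open" are said of these compounds alone.

In a functional assay on HepG2 cells (Homo sapiens) for cytotoxicity, read by MTT assay, with a stated time of 48 h (on this read-out lower numbers stand for stronger inhibition and higher numbers for weaker inhibition), compound 1, `CCCCOC(=O)/C=C/c1ccc2c(c1)C(=O)C(=O)N2Cc1ccc(OC)cc1`, gives 630 nM. Its only measured companion, compound 2, `COC(=O)/C=C/c1ccc2c(c1)C(=O)C(=O)N2Cc1ccc2ccccc2c1`, gives 90 nM. Compound 1 therefore holds the higher of the two numbers, and the gap between them lies beyond the usual scatter of repeated measurements. The two compounds differ in more than one place, so this gap cannot be assigned to any single change.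

The next compound to be tested in this assay is compound 3, `COc1ccc(CN2C(=O)C(=O)c3cc(/C=C/C(=O)N4CCCC4)ccc32)cc1`. Compared with compound 1, it carries pyrrolidin-1-yl in place of butoxy on a carbonyl carbon. Going by the values given here, no measured pair of compounds shows this exchange, so the data offer no direct precedent for its size or direction. Among the compounds with values here, the only anchor is compound 1 at 630 nM, and the expectation is a tentative one. The estimated step is a 2.4-fold higher number from compound 1 to compound 3 (0.38 log units; beyond the scatter), a moderate move toward a higher number and weaker inhibition. For compound 3, the expected value is 1500 nM, with an estimated range from 350 nM to 6500 nM.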

Compound 3, half-maximal inhibitory concentration: 7810 nM
The estimate for compound 3 lay 5.2-fold (0.72 log units) below the measured number; the measured number lies above the stated range.
By their numbers in this assay, from the lowest: compound 2; then compound 1; then compound 3.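

Going by these compounds alone, this is the first change that can be read at a single place. In this assay the exchange of butoxy for pyrrolidin-1-yl on a carbonyl carbon gives a 12-fold higher number from compound 1 to compound 3 (1.09 log units; beyond the scatter) and marks a large move toward weaker inhibition, whereas the earlier pair differed in more than one place and could assign nothing to this position. The step also shows that, in this one pair, the position does not tolerate every group of equal heavy-atom count, since butoxy and pyrrolidin-1-yl match on that count, but nothing shown here accounts for the loss.

The compounds shown leave open whether the step follows from the ring of pyrrolidin-1-yl or from the nitrogen that takes the place of oxygen on the carbonyl carbon, a question that an open-chain diethylamino group or a morpholin-4-yl group at the same place would bear on. They also leave open how a free carboxylic acid or a longer alkoxy chain would read there, and whether the same exchange would carry the same weight on the remainder of compound 2.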